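The source may hold more compounds than are shown below. What is called first, only, known or untested is meant among the compounds shown, and "the series" means these compounds.

Compound 3, `CN1CCN(c2nc(N)c(C(=O)N=C(N)N)nc2Cl)CC1`, is the starting point of this step, but in an assay for inhibition of acid-sensing ion channel 3 (Homo sapiens), read by patch clamp, tested at 1 uM (on this read-out lower numbers stand for less inhibition and higher numbers for more inhibition at the one concentration tested (going by the name of the read-out)), compound 3 gives "not determined" (no result reported) and so has no single number to stand on. The other members of the series do have numbers. Compound 1, `C=CCNc1nc(N)c(C(=O)N=C(N)N)nc1Cl`, gives 16% in this assay, and compound 2, `CCCNc1nc(N)c(C(=O)N=C(N)N)nc1Cl`, gives 24% there. Among the compounds with values here, the one step between measured neighbours, a number 8 percentage points higher from compound 1 to compound 2 (within the scatter), concerns an ethyl in place of a vinyl on a saturated chain carbon bound to a nitrogen on an aromatic ring and lies within the scatter, so it says nothing about a change of the kind now in view. The step to compound 4, `NC(N)=NC(=O)c1nc(Cl)c(Nc2ccccc2)nc1N`, is anilino in place of 4-methylpiperazin-1-yl on an aromatic carbon. Within the data shown here, no measured step bears on an anilino group entering where a 4-methylpiperazin-1-yl group leaves, and compound 3 itself has no value, so the expectation for compound 4 can rest only on the small range that compound 1 and compound 2 span in this assay. Compound 4 is therefore estimated at 25%, within a wide range from 5% to 50%, with no direction beyond the scatter claimed.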

Compound 4, a percentage reported as inhibition, at one concentration (the size of the read-out at that concentration, not a potency): 44%
Compound 4: the middle estimate sits 19 percentage points below what was measured, and the stated range covers the measured number.
By their numbers in this assay, from the lowest: compounds 1 and 2 (each within the scatter of the next); then compound 4.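

In this assay, changing the group on the nitrogen at this aromatic carbon now gives a difference beyond the scatter, with phenyl in place of propyl giving a number 20 percentage points higher from compound 2 to compound 4 (beyond the scatter) and phenyl in place of allyl giving a number 28 percentage points higher from compound 1 to compound 4 (beyond the scatter) in the same direction. The phenyl ring on this nitrogen therefore sets compound 4 apart from both open-chain compounds, something the step between those two chains did not show. The step from compound 3 to compound 4 cannot be read, and nothing measured here accounts for the difference from the chains.

As far as these compounds go, how the anilino group compares with the 4-methylpiperazin-1-yl group at this place stays open. So does whether a benzylamino group, or an anilino ring carrying a methoxy group, would read differently from compound 4.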